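The compounds below may be only part of what the source reports. "The series", "measured", "known", "first", "only" and "open" are said of these compounds alone.

Compound 1 `CC(C)c1onc(-c2c(Cl)cccc2Cl)c1COc1ccc(-c2nc3ccc(C(=O)O)cc3n2Cc2ccc(F)cc2)cc1` is the reference point here. Within the data shown here, in an assay on isolated protein for agonist activity at Bile acid receptor (Homo sapiens), read by TR-FRET (on this read-out lower numbers stand for an effect already at smaller amounts and higher numbers for an effect only at larger amounts of compound), compound 1 gives 105 nM, which is the only number available. In this assay compound 2 `CC(C)c1onc(-c2c(Cl)cccc2Cl)c1COc1ccc(-c2nc3ccc(C(=O)O)cc3n2CC2CCCCC2)c(F)c1` gives "not determined" (no result reported), so no number is available for it. Compound 3 `CCn1c(-c2ccc(OCc3c(-c4c(Cl)cccc4Cl)noc3C(C)C)cc2)nc2ccc(C(=O)O)cc21` differs from compound 1 by methyl in place of 4-fluorophenyl on a saturated chain carbon bound to an aromatic nitrogen. Among the measured compounds shown here, no step between measured compounds exists to anchor this change. On that change alone, the step of a 4.8-fold higher number from compound 1 to compound 3 (0.68 log units; beyond the scatter) is expected to be a loss beyond the scatter. Compound 3 is accordingly estimated at 500 nM, with a range from 150 nM to 2500 nM.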

Compound 3, half-maximal effective concentration: 19.3 nM
Compound 3: middle estimate off by 26-fold (1.41 log units), on the high side, and the stated range ends above it.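

At this position the aromatic ring of the 4-fluorobenzyl group is not required for activity: in this assay, the change to ethyl gives a 5.4-fold lower number from compound 1 to compound 3 (0.74 log units; beyond the scatter) and so the far smaller group is the better of these two. No measurement shown here offers an explanation for this gain.

With only these two substituents compared, no dependence on chain size can be drawn. From the compounds shown here alone, how a propyl chain, a cyclopropylmethyl group or a chain carrying an amine would fare at this position remains open.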